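The compounds below may be only part of what the source reports. "The series", "measured", "known", "first", "only" and "open" are said of these compounds alone.

Compound 1 `N#Cc1cnc(NCc2cnccc2C(F)(F)F)cc1N[C@H]1CC[C@H](O)CC1` has the highest number of the two measured here; in an assay on isolated protein for inhibition of protein kinase C theta type (Homo sapiens), read by TR-FRET, with a stated time of 2 h (a lower number here means a stronger inhibitor, a higher number a weaker inhibitor), compound 1 gives 350 nM. Compound 2 `CN(C)C(=O)[C@H]1CC[C@@H](Nc2cc(NCc3cnccc3C(F)(F)F)ncc2C#N)CC1` gives 38 nM in this assay, a lower number and so a stronger inhibitor, beyond the usual scatter. Compound 3 `CC1(C)[C@@H](Nc2cc(NCc3cnccc3C(F)(F)F)ncc2C#N)C[C@@H]1C(N)=O` differs from compound 1 by 3-carbamoyl-2,2-dimethylcyclobutyl in place of 4-hydroxycyclohexyl on a nitrogen on an aromatic ring. For the measured compounds named here, no measured pair covers this change, so the expectation rests on compound 2, whose value 38 nM shows that altering this same group on compound 1 can lower the number well beyond the scatter. The step of a 2.9-fold lower number from compound 1 to compound 3 (0.46 log units; beyond the scatter) is expected to be a moderately lower number. Compound 3 is expected to give about 120 nM, within 40 nM to 400 nM.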

Compound 3, half-maximal inhibitory concentration: 1100 nM
Beside the measured number, compound 3's estimate is 9.2-fold (0.96 log units) below it; measured number above the stated range.
By their numbers in this assay, from the lowest: compound 2; then compound 1; then compound 3.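

In this assay, 3-carbamoyl-2,2-dimethylcyclobutyl in place of 4-hydroxycyclohexyl gives a 3.1-fold higher number from compound 1 to compound 3 (0.50 log units; beyond the scatter) and so a weaker inhibitor, showing that a change on this nitrogen can also raise the number, whereas compound 2 had shown only a lower one. The two groups match in hydrogen-bond donors and acceptors, yet the numbers still differ beyond the scatter. Nothing measured here accounts for this rise. Still open, as far as these compounds go, is whether the four-membered ring, the two methyl groups or the carbamoyl group drives the step. A plain cyclobutyl or a cyclohexyl bearing a carbamoyl group would help separate them.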